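Amine Variation on the Side Chain of the Series

This account rests on a few compounds, and the source may have more. Where it says the series, first, only, none or still open, it means among the compounds named here.

Compound 1 `CN(C)CCn1c(N)c(-c2nc3ccccc3n2C)c2nc(C#N)c(C#N)nc21` carries a dimethylamino group two bonds along the chain from an aromatic nitrogen. In a functional assay on HeLa cells (Homo sapiens) for antiproliferative activity, read by MTT assay, with a stated time of 48 h (on this read-out higher numbers stand for weaker inhibition and lower numbers for stronger inhibition), compound 1 gives only a limit, > 50000 nM. Compound 2 `CCN(CC)CCn1c(N)c(-c2nc3ccccc3n2C)c2nc(C#N)c(C#N)nc21` differs from it by diethylamino in place of dimethylamino on a saturated chain carbon, two bonds along the chain from an aromatic nitrogen. In this assay compound 2 also returns a limit, > 50000 nM. Because both sit at the limit of > 50000 nM in this assay, at which 2 of the 3 values shown sit, the step that the two limits leave unreadable from compound 1 to compound 2 has no readable size or direction.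

Compound 3 `CN(C)CCCCn1c(N)c(-c2nc3cc(Cl)ccc3[nH]2)c2nc(C#N)c(C#N)nc21` is built on another core; the difference between the two cores is not broken down here. In this assay, within the data shown here, compound 3 gives 3120 nM, the only number in the set.

Compound 4 `CCN(CC)CCCCn1c(N)c(-c2nc3cc(Cl)ccc3[nH]2)c2nc(C#N)c(C#N)nc21` is not yet measured and differs from compound 3 by diethylamino in place of dimethylamino on a saturated chain carbon, four bonds along the chain from an aromatic nitrogen. Among the measured compounds shown here, this is the same kind of change as the one from compound 1 to compound 2, but not the same: there the amine sits two bonds along the chain from an aromatic nitrogen, here four bonds along the chain. The measured precedent offers no readable size, as both of its members sit at the limit. With nothing pointing to a large shift, the step from compound 3 to compound 4 is expected to be small, a 1.1-fold higher number from compound 3 to compound 4 (0.05 log units; within the scatter). For compound 4 in this assay the expected value is 3500 nM, with a range from 1200 nM to 10000 nM. This estimate rests on compound 3, which gives 3120 nM.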

Compound 4, half-maximal inhibitory concentration: 3640 nM
Beside the measured number, compound 4's estimate is 1.0-fold (0.02 log units) below it; measured number inside the range.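

In this assay, diethylamino in place of dimethylamino, four bonds along the chain from an aromatic nitrogen, gives a 1.2-fold higher number from compound 3 to compound 4 (0.07 log units; within the scatter), so on the core of compound 3 this change does not separate the two compounds. On the core of compound 1, with the amine two bonds along the chain from an aromatic nitrogen, the same exchange cannot be read, and no size or direction can be set beside the new step, because both members of that pair sit at a limit of the assay rather than at a number: the limit of > 50000 nM in this assay, at which 2 of the 4 values shown sit. The new step therefore shows tolerance of the larger amine in one setting only and does not show that the change carries from one core to another; the two pairs also differ in both core and chain, so any effect of the core cannot be told apart from one of the chain.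

On these data alone, it remains open whether a cyclic amine such as pyrrolidine, piperidine or morpholine at the end of the same chain would stay within the scatter of compound 3. Also open, as far as these compounds go, is how a carboxylic acid in place of the amine, or a longer chain carrying diethylamino, would read in this assay.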